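Nitro for Methyl on a Second Core

This account rests on a few compounds, and the source may have more. Where it says the series, first, only, none or still open, it means among the compounds named here.

Compound 1 `Cc1ccc(N2CCN(CCCn3nc(-c4ccccc4)c(C#N)c3C)CC2)cc1` was tested in a functional assay on the whole organism (Abdomen, strain Swiss) for inhibition, with Mus musculus as the target, with stated times of 30 min, 10 min and 5 min, at a dose of 20 mg/kg by the oral route (on this read-out lower numbers stand for a weaker effect and higher numbers for a stronger effect at the one dose given), where compound 1 gives 8%. Compound 2 `Cc1c(C#N)c(-c2ccccc2)nn1CCCN1CCN(c2ccc([N+](=O)[O-])cc2)CC1` differs from it by one change (nitro in place of methyl on an aromatic carbon), and in this assay compound 2 gives 21%, a step of a number 13 percentage points higher from compound 1 to compound 2 (beyond the scatter). Compound 3 `CC(=O)c1cccn1CCCN1CCN(c2ccc(C)cc2)CC1` carries a different core, and the difference between the two cores is not broken down here. In this assay compound 3 gives 7%. Compound 4 `CC(=O)c1cccn1CCCN1CCN(c2ccc([N+](=O)[O-])cc2)CC1` has not yet been measured and differs from compound 3 by the same change (nitro in place of methyl on an aromatic carbon), at the same place. Within the data shown here, the step is expected to be a number 11 percentage points higher from compound 3 to compound 4 (beyond the scatter), close to the earlier one, because the only measured example of this change is a number 13 percentage points higher from compound 1 to compound 2 (beyond the scatter). That example comes from a single pair on another core, so the expectation is loose. Compound 4 is therefore expected to give about 18%, between 5% and 32%.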

Compound 4, a percentage reported as inhibition, in the whole organism at one dose (the size of the read-out at that dose, not a potency): 11%
Beside the measured number, compound 4's estimate is 7 percentage points above it, and the stated range covers the measured number.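

In this assay, putting nitro in place of methyl on the second core gives a number 4 percentage points higher from compound 3 to compound 4 (within the scatter), so on this core the change has no effect that can be told apart from ordinary repeat variation. Set beside the first core, the two results do not clearly disagree: the same change on two cores in this assay, a number 13 percentage points higher (beyond the scatter) from compound 1 to compound 2 and a number 4 percentage points higher (within the scatter) from compound 3 to compound 4, 9 percentage points apart, within the scatter of two such steps This means the change may carry over from one core to the other, but with only one pair per core it does not show that it does, or that the gain seen on the first core appears on the second.

The compounds shown leave open how an amine or a carboxylic acid would behave at the same place on the ring. They also leave open whether the comparison would look the same at another dose.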